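Adding an amide chain to compound 1

The compounds below may be only part of what the source reports. "The series", "measured", "known", "first", "only" and "open" are said of these compounds alone.

Compound 1 `CCOc1ccccc1-c1ccc(-c2nc3cnccc3cc2C#N)cc1`: 3.8
Compound 2 `CC[C@@H](Nc1c(C#N)c(-c2ccc(-c3cccc(Cl)c3F)cc2)nc2cnccc12)C(N)=O`: 3.1
Compound 3 `CC[C@@H](Nc1c(C#N)c(-c2ccc(-c3ccc(F)cc3)cc2)nc2cnccc12)C(N)=O`: 2.7

These numbers come from a physicochemical assay for lipophilicity, read by HPLC, at pH 7.5; a higher number here means a more lipophilic compound, a lower number a more polar compound. Compound 1, at 3.8, stands highest of the three, and its gaps down to compound 2 and compound 3 are both beyond the usual scatter.

The next compound, compound 4 `CCOc1ccccc1-c1ccc(-c2nc3cnccc3c(C[C@H](C)C(N)=O)c2C#N)cc1`, has not been measured yet. It is compound 1 with a single change: 2-carbamoylpropyl in place of hydrogen on an aromatic carbon. In plain terms, a 2-carbamoylpropyl chain replaces a hydrogen on an aromatic carbon, ortho to a cyano group and opposite the ring nitrogen.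

Among the compounds with values here, only one measured step exists, a number 0.40 log units lower from compound 2 to compound 3 (beyond the scatter). It swaps 3-chloro-2-fluorophenyl for 4-fluorophenyl, so it shows a modest shift from a different kind of change and does not isolate the effect of adding a chain. The closer guide is that compound 2 at 3.1 and compound 3 at 2.7 both carry a chain ending in an amide. Both read lower than compound 1, although they also differ from it elsewhere, so this evidence is indirect.

A fall is therefore expected, and the estimated step is a number 0.60 log units lower from compound 1 to compound 4 (beyond the scatter). For compound 4 the estimated value is 3.2, with an expected range from 2.7 to 3.7.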

Compound 4, distribution coefficient: 3
The estimate for compound 4 lay 0.20 log units above the measured number; low and high end bracket the measured number.
By their numbers in this assay, from the lowest: compounds 3, 4 and 2 (each within the scatter of the next, the first and the last beyond it); then compound 1.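

Compounds 2 and 3 carry an amide chain but also differ from compound 1 elsewhere, so they could not show what such a chain does on its own. Within the data shown here, compound 4 supplies that reading: in this assay, adding 2-carbamoylpropyl in place of hydrogen is the only structural change, and it gives a number 0.80 log units lower from compound 1 to compound 4 (beyond the scatter). This shows that, on the core of compound 1, placing this chain on the aromatic carbon ortho to a cyano group and opposite the ring nitrogen lowers the number by itself, although no supporting measurement bears on the cause of the fall.

This single pair cannot separate the contribution of the carbon chain from that of the terminal amide, and a plain propyl chain at the same position would allow the two to be told apart. A carboxylic acid or an amine at the end of the chain, or a longer chain, could also give a different step, and the compounds shown say nothing about any of these groups.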